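Piperidin-3-ylamino replacing cyclobutylpiperazinyl on the shared core

The source may hold more compounds than are shown below. What is called first, only, known or untested is meant among the compounds shown, and "the series" means these compounds.

Measured so far:
compound 1 `CN(c1nc2c(c(Nc3ccc(C(F)(F)F)cc3)n1)CCN(c1ncccc1C(F)(F)F)CC2)C1CCCNC1`: 1540 nM
compound 2 `FC(F)(F)c1ccc(Nc2nc(N3CCN(C4CCC4)CC3)nc3c2CCN(c2ncccc2C(F)(F)F)CC3)cc1`: 161 nM

In a functional assay on HEK293 cells for antagonist activity at transient receptor potential cation channel subfamily V member 1 (Rattus norvegicus), read by FLIPR and calcium flux (on this read-out lower numbers stand for stronger inhibition and higher numbers for weaker inhibition), compound 2 stands at the lowest of the two numbers; the nearest is compound 1, a 9.6-fold lower number from compound 1 to compound 2 (0.98 log units; beyond the scatter) step away. Compound 3 `FC(F)(F)c1ccc(Nc2nc(NC3CCCNC3)nc3c2CCN(c2ncccc2C(F)(F)F)CC3)cc1` is not yet measured. The change from compound 2 to compound 3 is (piperidin-3-yl)amino in place of 4-cyclobutylpiperazin-1-yl on an aromatic carbon. Within the data shown here, only one measured step bears on this place: the step of a 9.6-fold lower number from compound 1 to compound 2 (0.98 log units; beyond the scatter), where the methyl(piperidin-3-yl)amino group of compound 1 was exchanged for the 4-cyclobutylpiperazin-1-yl group of compound 2. As far as these compounds go, compound 3 carries a group that differs from that of compound 1 only by the missing methyl on the amino nitrogen, so compound 3 is expected to move back toward compound 1 rather than stay with compound 2, though the exact size of the loss of methyl is unknown. For compound 3 the expected step is a 5.6-fold higher number from compound 2 to compound 3 (0.75 log units; beyond the scatter). The estimate for compound 3 in this assay is 900 nM, within 300 nM to 3000 nM.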

Compound 3, half-maximal inhibitory concentration: > 5000 nM
Compound 3 gave a limit, no number; the forecaster's own chance of this, stated with the estimate: 5%; middle value at least 5.5-fold (0.74 log units) away from the limit.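

Compound 3 returns a limit, not a number, in this assay: the limit of > 5000 nM in this assay, at which 1 of the 3 values shown sits.

Hydrogen in place of methyl on the amino nitrogen is not a silent edit at this position: the step is an at least 3.2-fold higher number from compound 1 to compound 3 (0.51 log units; beyond the scatter), so this single change already reads beyond the scatter, and toward weaker inhibition. Set against the 4-cyclobutylpiperazin-1-yl group, the (piperidin-3-yl)amino group gives an at least 31-fold higher number from compound 2 to compound 3 (1.49 log units; beyond the scatter), which places the two amino-linked piperidines of the series on the weaker side of compound 2.

The compounds shown do not separate the contribution of the linking amino nitrogen from that of the piperidine ring. A 4-methylpiperazin-1-yl group, or an open-chain amine such as dimethylamino, on the same aromatic carbon would bear on that question.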